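Ring-amine substituent in the urea series

The compounds below may be only part of what the source reports. "The series", "measured", "known", "first", "only" and "open" are said of these compounds alone.

Within the data shown here, compound 2 `O=C(Nc1ccc(OC(F)(F)F)cc1)Nc1cccnc1Oc1cccc2c1CCNC2` gives 3000 nM in an assay on HEK293 cells for displacement of a labelled ligand from P2Y purinoceptor 1 (Homo sapiens), read by scintillation counting, with a stated time of 1 h (a higher number here means a weaker inhibitor, a lower number a stronger inhibitor), the higher of the two numbers known so far. Compound 1 `CC(C)N1CCc2c(cccc2Oc2ncccc2NC(=O)Nc2ccc(OC(F)(F)F)cc2)C1` gives 560 nM in this assay. Among the measured compounds shown here, the one measured step between them, a 5.4-fold higher number from compound 1 to compound 2 (0.73 log units; beyond the scatter), shows that the compound lacking the isopropyl on the ring amine is the weaker inhibitor. Compound 3 `CC(C)(C)CCN1CCc2c(cccc2Oc2ncccc2NC(=O)Nc2ccc(OC(F)(F)F)cc2)C1` carries the change (3,3-dimethylbutyl in place of hydrogen on an amine nitrogen in a ring); the entering group brings no ring, no hydrogen-bond donors or acceptors and no net charge, on the amine nitrogen in a ring of a six-membered non-aromatic ring within the fused system. For the measured compounds named here, only the step from compound 1 to compound 2 bears on this; it ran the other way and was modest. Restoring an alkyl substituent at that position is expected to lower the number. A step of about the size of the measured one is expected, a 6.7-fold lower number from compound 2 to compound 3 (0.82 log units; beyond the scatter). Compound 3 is therefore estimated at 450 nM, with a range from 120 nM to 1700 nM.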

Compound 3, inhibition constant: 190 nM
Compound 3: middle estimate off by 2.4-fold (0.37 log units), on the high side; low and high end bracket the measured number.
By their numbers in this assay, from the lowest: compound 3; then compound 1; then compound 2.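

In this assay the 3,3-dimethylbutyl group on the amine nitrogen in a ring gives a 16-fold lower number from compound 2 to compound 3 (1.20 log units; beyond the scatter) and so shows that the gain from an alkyl group at this nitrogen is not confined to isopropyl. The identity of the alkyl group also matters here, as a 2.9-fold lower number from compound 1 to compound 3 (0.47 log units; beyond the scatter) is a further step beyond the scatter. Across the three compounds the number falls in the order hydrogen, isopropyl, 3,3-dimethylbutyl, and none of them goes against that order.

On these data alone, whether the number keeps falling with a longer chain stays open, as does the outcome with a benzyl group or a chain ending in an amine or a carboxylic acid on that nitrogen. The compounds shown also leave open whether these steps hold when another part of the shared core changes. No measurement at hand gives a reason for either step.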